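A Longer Chain to the Hydroxycarbamoyl Group in Compound 1

The source may report more compounds than this note shows. Statements on the series, on what has been measured and on what is new or still open speak of the compounds shown alone.

Among the measured compounds shown here, compound 1 `COc1cc2c(Oc3ccc(NC(=O)c4nn(-c5ccccc5C)cc(C)c4=O)cc3)ccnc2cc1OCCCCCC(=O)NO` gives 290 nM in a functional assay on HCT-116 cells (Homo sapiens) for inhibition, read by MTT assay, with a stated time of 72 h (a lower number here means a stronger inhibitor, a higher number a weaker inhibitor), the lowest of the three numbers measured so far. Compound 2 `COc1cc2c(Oc3ccc(NC(=O)c4nn(-c5ccccc5C)ccc4=O)cc3)ccnc2cc1OCCCCCC(=O)NO` gives 700 nM in this assay, and compound 3 `COc1cc2c(Oc3ccc(NC(=O)c4nn(-c5ccccc5F)cc(C)c4=O)cc3F)ccnc2cc1OCCCC(=O)NO` gives 1120 nM. For the measured compounds named here, the only single-point step, a 2.4-fold higher number from compound 1 to compound 2 (0.38 log units; beyond the scatter), concerns a methyl group on a ring and says nothing about the chain. Compound 4 `COc1cc2c(Oc3ccc(NC(=O)c4nn(-c5ccccc5C)cc(C)c4=O)cc3)ccnc2cc1OCCCCCCC(=O)NO` differs from compound 1 by (hydroxycarbamoyl)methyl in place of hydroxycarbamoyl on a saturated chain carbon, five bonds along the chain from an oxygen on an aromatic ring. Compound 3 differs from compound 1 in several places at once, so it offers no clean comparison for this change. Going by the values given here, with no measured step bearing on it, a step of about a 1.3-fold higher number from compound 1 to compound 4 (0.12 log units; within the scatter) is expected, within the scatter but leaning toward a higher number. Compound 4 is therefore estimated at 380 nM, between 150 nM and 1000 nM.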

Compound 4, half-maximal inhibitory concentration: 660 nM
For compound 4 the middle estimate is 1.7-fold (0.24 log units) below the measured one, within the range that was stated.
By their numbers in this assay, from the lowest: compound 1; then compounds 4, 2 and 3 (each within the scatter of the next).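

Replacing hydroxycarbamoyl with (hydroxycarbamoyl)methyl at this saturated chain carbon gives a 2.3-fold higher number from compound 1 to compound 4 (0.36 log units; beyond the scatter) in this assay. Among the compounds shown here, this is the first clean reading of chain length in this set, and it shows that the longer chain on the core of compound 1 moves the number modestly but beyond the scatter. Nothing measured here offers a reason for this step. Still open, going by these compounds, is whether a shorter chain, 4-(hydroxycarbamoyl)butyl, on the same core would give a lower number or a higher one. Also open, on these data alone, is how a carboxylic acid in place of hydroxycarbamoyl would read in this assay.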